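The source may hold more compounds than are shown below. What is called first, only, known or untested is meant among the compounds shown, and "the series" means these compounds.

Compound 1 `O=C1COc2ccc(-c3cnc4ccccc4c3)cc2N1C1CCCCC1` carries a cyclohexyl group on an amide-type nitrogen in a ring. In a functional assay on HCT-116 cells (Homo sapiens) for antiproliferative activity, read by MTT assay, with a stated time of 72 h (on this read-out lower numbers stand for stronger inhibition and higher numbers for weaker inhibition), compound 1 reaches only a limit, > 40000 nM. Compound 2 `Cc1ccc(N2C(=O)COc3ccc(-c4cnc5ccccc5c4)cc32)cc1` likewise stops at a limit in this assay, > 40000 nM. The change between the two, (4-methylphenyl in place of cyclohexyl on an amide-type nitrogen in a ring), thus produced a step that the two limits leave unreadable from compound 1 to compound 2; what the pair shows is only (the limit of > 40000 nM in this assay, at which 2 of the 3 values shown sit). Compound 3 `O=C1COc2ccc(-c3cccc(NS(=O)(=O)c4ccc(F)cc4)c3)cc2N1C1CCCCC1`, in contrast, gives a number in this assay, 18300 nM. The difference between the core of compound 3 and that of compound 1 is not broken down here. Compound 4 `Cc1ccc(N2C(=O)COc3ccc(-c4cccc(NS(=O)(=O)c5ccc(F)cc5)c4)cc32)cc1` is not yet measured; it differs from compound 3 by 4-methylphenyl in place of cyclohexyl on an amide-type nitrogen in a ring, the same change as from compound 1 to compound 2, whose size could not be read. Compound 4 is therefore expected to stay close to compound 3, with a step of a 1.4-fold higher number from compound 3 to compound 4 (0.14 log units; within the scatter) in this assay. The estimate for compound 4 is 25000 nM, between 8000 nM and 80000 nM.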

Compound 4, half-maximal inhibitory concentration: 35600 nM
Beside the measured number, compound 4's estimate is 1.4-fold (0.15 log units) below it; the range from low to high includes it.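

In this assay, 4-methylphenyl in place of cyclohexyl on the amide-type nitrogen in a ring gives a 1.9-fold higher number from compound 3 to compound 4 (0.29 log units; within the scatter), so on the core of compound 3 this change leaves the two compounds within the usual scatter of each other. The same change on the core of compound 1 cannot be read, because both values there are limits of the assay and not numbers: the limit of > 40000 nM in this assay, at which 2 of the 4 values shown sit. The series therefore offers one readable pair, which does not show that the change has the same size on both cores. The compounds shown leave open whether a different group on that nitrogen, such as an amine or a carboxylic acid on a longer chain, would give a step beyond the scatter.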